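A few compounds are considered here, and "the series" means these few. Any claim that something is new, unique, unknown or untested is made for them only; others in the source may bear on it.

Compound 1, `O=C(NCc1ccc(F)c(F)c1)c1cccc(O)c1O`: in an ADME assay on NCI-H630 cells (Homo sapiens) for cytotoxicity, read by MTT assay, with a stated time of 72 h (a higher number here means that more compound is tolerated, a lower number that less compound is tolerated), compound 1 gives > 40000 nM, which is a limit of the assay rather than a number.
Compound 2, `O=C(NCc1cccs1)c1cccc(O)c1O`: in this assay compound 2 gives > 40000 nM, again a limit of the assay and not a number.

Compound 2 therefore stands at the edge of what was measured, not at a point on a scale, and the two measured compounds both sit at the limit of > 40000 nM in this assay, at which 2 of the 2 values shown sit. Compound 3, `O=C(NCc1ccco1)c1cccc(O)c1O`, differs from compound 2 in one place: furan-2-yl in place of thiophen-2-yl on a saturated chain carbon bound to an amide-type nitrogen. No step between measured compounds is on record, so nothing shown sizes the effect of such a change. With both measured values resting at the same limit, the expected step from compound 2 to compound 3 in this assay is a step that the limit leaves unreadable from compound 2 to compound 3, that is, none beyond the usual scatter. Compound 3 is accordingly estimated at 50000 nM, within 20000 nM to 150000 nM, most likely reported once more as a limit.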

Compound 3, half-maximal cytotoxic concentration: > 40000 nM
Compound 3: a limit, no number (the forecaster's own chance of this, stated with the estimate: 85%); the middle value lies beyond the limit too.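

Within the data shown here, compound 2 and compound 3 each give a limit rather than a number, so no step between them can be read: the limit of > 40000 nM in this assay, at which 3 of the 3 values shown sit. The compounds shown leave open how much compound is tolerated beyond that limit in this assay, and whether furan-2-yl and thiophen-2-yl differ there at all.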